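A few compounds are considered here, and "the series" means these few. Any claim that something is new, unique, unknown or untested is made for them only; others in the source may bear on it.

Measured so far:
Compound 1 `CN1CCN(c2ccc(S(=O)(=O)Oc3cccc(F)c3)cc2)C1=O` gives > 100000 nM in a functional assay on MCF7 cells (Homo sapiens) for antiproliferative activity, read by sulforhodamine B assay, with a stated time of 48 h; on this read-out lower numbers stand for stronger inhibition and higher numbers for weaker inhibition; this is a limit of the assay, not a number.
Compound 2 `CN1CCN(c2ccc(S(=O)(=O)Oc3cccc(Cl)c3)cc2)C1=O` gives 2200 nM in this assay.
Compound 3 `CN1CCN(c2ccc(S(=O)(=O)Oc3ccc(F)cc3)cc2)C1=O` gives > 100000 nM in this assay; this is a limit of the assay, not a number.

Two of the three values sit at the limit of > 100000 nM in this assay, at which 2 of the 3 values shown sit. Within the data shown here, the one readable change is chloro in place of fluoro on an aromatic carbon, which produced an at least 45-fold lower number from compound 1 to compound 2 (1.65 log units; beyond the scatter). The difference between the two cores is 4-fluorophenyl in place of 3-fluorophenyl on an oxygen; the step that the two limits leave unreadable from compound 1 to compound 3 is not readable, as both ends are limits. From compound 2 to compound 3 the step is an at least 45-fold higher number from compound 2 to compound 3 (1.65 log units; beyond the scatter).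

Compound 4 `CN1CCN(c2ccc(S(=O)(=O)Oc3ccc(Cl)cc3)cc2)C1=O` is not yet measured. It differs from compound 3 by chloro in place of fluoro on an aromatic carbon. This is the same kind of change as that from compound 1 to compound 2, but the place differs: there meta to a large group, here para to a large group. For compound 4 a step of an at least 20-fold lower number from compound 3 to compound 4 (1.30 log units; beyond the scatter) in this assay is expected, resting on the step of an at least 45-fold lower number from compound 1 to compound 2 (1.65 log units; beyond the scatter) and on compound 3 sitting at a limit, > 100000 nM; the new value is expected to be 5000 nM, with a range from 1000 nM to 100000 nM.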

Compound 4, half-maximal inhibitory concentration: > 100000 nM
Compound 4 ended at the assay's limit; the forecaster's own chance of this, stated with the estimate: 30%; middle value at least 20-fold (1.30 log units) from the limit.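

In this assay compound 4 gives > 100000 nM, which is a limit of the assay and not a number. The steps from compound 3 to compound 4 and from compound 1 to compound 4 cannot be read, because both ends of each are limits: the limit of > 100000 nM in this assay, at which 3 of the 4 values shown sit. Chloro in place of fluoro gave a readable value in one core, an at least 45-fold lower number from compound 1 to compound 2 (1.65 log units; beyond the scatter), but not in the other, where 4-chlorophenyl in place of 3-chlorophenyl on the oxygen gives an at least 45-fold higher number from compound 2 to compound 4 (1.65 log units; beyond the scatter); the change therefore did not carry over to a value inside the assay's range, and whether it has any effect at all on the core of compound 3 is not shown.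

Among these compounds, compound 2, at 2200 nM, remains the only compound here with a readable value, so it is open whether that value depends on chloro itself. Bromo, methyl or an amine in place of the chloro of compound 2 would bear on this, and none of them is among the compounds shown.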